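Dichlorophenyl Swap in a Cytotoxicity Series: Working Notes

This account rests on a few compounds, and the source may have more. Where it says the series, first, only, none or still open, it means among the compounds named here.

Measured in a functional assay on HepG2 cells (Homo sapiens) for cytotoxicity, read by MTT assay, with a stated time of 24 h; a higher number here means a weaker inhibitor, a lower number a stronger inhibitor:
- compound 1, `COc1cc(/C=C2\CN(C)C/C(=C\c3ccc(Cl)cc3Cl)C2=O)cc(OC)c1OC`: 8800 nM
- compound 2, `COc1cc(/C=C2\CN(C)C/C(=C\c3ccc(Cl)c(Cl)c3)C2=O)cc(OC)c1OC`: 6960 nM
- compound 3, `CN1C/C(=C\c2cccc([N+](=O)[O-])c2)C(=O)/C(=C/c2ccc(Cl)cc2Cl)C1`: 4800 nM

Compound 1 and compound 2 share one core; compound 3 and compound 4, `CN1C/C(=C\c2cccc([N+](=O)[O-])c2)C(=O)/C(=C/c2ccc(Cl)c(Cl)c2)C1`, share another. The difference between the two cores is not broken down here.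

Compound 2 differs from compound 1 in one place:
3,4-dichlorophenyl in place of 2,4-dichlorophenyl on a double-bonded chain carbon bound to a double-bonded ring carbon
In this assay this gave a 1.3-fold lower number from compound 1 to compound 2 (0.10 log units; within the scatter). Compound 4 differs from compound 3 by the same change, at the same place:
3,4-dichlorophenyl in place of 2,4-dichlorophenyl on a double-bonded chain carbon bound to a double-bonded ring carbon

In this assay the values of compound 1, compound 2 and compound 3 all lie within the usual scatter of one another, so no order among the three is claimed.

Going by the values given here, only one measured instance of the swap exists, and it is within the scatter. Among the compounds with values here, on that basis the step is expected to be small: a 1.3-fold lower number from compound 3 to compound 4 (0.11 log units; within the scatter), resting on the single measured step of a 1.3-fold lower number from compound 1 to compound 2 (0.10 log units; within the scatter). Compound 4 is therefore estimated at 3700 nM in this assay, with a range from 1800 nM to 7500 nM.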

Compound 4, half-maximal inhibitory concentration: 5960 nM
The estimate for compound 4 lay 1.6-fold (0.21 log units) below the measured number; low and high end bracket the measured number.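

In this assay, putting 3,4-dichlorophenyl in place of 2,4-dichlorophenyl gives a 1.2-fold higher number from compound 3 to compound 4 (0.09 log units; within the scatter), so on this second core the step again stays within the scatter. Set side by side, the two instances of the swap do not differ beyond what two such steps can show: the same change on two cores in this assay, a 1.3-fold lower number (0.10 log units; within the scatter) from compound 1 to compound 2 and a 1.2-fold higher number (0.09 log units; within the scatter) from compound 3 to compound 4, 1.6-fold (0.20 log units) apart, within the scatter of two such steps. On these two cores the swap therefore carries over as a step too small to read, but this shows neither a direction for the change nor that it would stay this small on any further core.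

The compounds shown leave open whether a readable step would appear with a phenyl bearing an amine or a carboxylic acid in place of the chlorines. Also open, from the compounds shown here alone, is how the swap behaves on a core carrying a longer chain, and which of the differences between the two cores, if any, bears on these values.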